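A Sulfanyl for Amino Swap on an Inactive Core

A few compounds are considered here, and "the series" means these few. Any claim that something is new, unique, unknown or untested is made for them only; others in the source may bear on it.

Of the compounds shown here, three have so far been tested in a functional assay on KB cells (Homo sapiens) for inhibition; a lower number here means a stronger inhibitor, a higher number a weaker inhibitor. Compound 1, `OCC(CO)OCn1c(SCc2ccccc2)nc2cc(Cl)c(Cl)cc21`, gives > 100000 nM, which is a limit of the assay and not a number. Compound 2, `Nc1nc2c(Cl)c(Cl)ccc2n1COC(CO)CO`, gives > 100000 nM, likewise a limit. Compound 3, `OCC(CO)OCn1c(S)nc2c(Cl)cc(Cl)cc21`, gives > 100000 nM, again a limit. Compound 2 therefore stands at the same point as the other two: all three values sit at the limit of > 100000 nM in this assay, at which 3 of the 3 values shown sit, so no ranking among them is possible and none can be called stronger or weaker.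

Compound 4, `OCC(CO)OCn1c(S)nc2c(Cl)c(Cl)ccc21`, has not yet been measured. It differs from compound 2 by sulfanyl in place of amino on an aromatic carbon. Within the data shown here, no pair of measured compounds differs in just this way, so the size of this step cannot be read from a measured pair. Compound 3 carries the same sulfanyl group on a related core and also reports only a limit, which gives no hint that the sulfanyl group brings potency into measurable range. The change is therefore expected to be none beyond the scatter, a step that the limit leaves unreadable from compound 2 to compound 4. Compound 4 is expected to give about 150000 nM in this assay, with a range from 60000 nM to 400000 nM, and most likely to report only a limit once more.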

Compound 4, half-maximal inhibitory concentration: > 100000 nM
Compound 4 ended at the assay's limit; the forecaster's own chance of this, stated with the estimate: 85%; the middle value lies beyond the limit too.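

Compound 2 and compound 4 each report only a limit, so no step can be read for sulfanyl in place of amino, and the comparison ends with all the compounds at the same point: the limit of > 100000 nM in this assay, at which 4 of the 4 values shown sit. What the compounds shown leave open is whether, in this assay, any change to this shared core can give a measurable value.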